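Tetrazole for methylsulfonyl: solubility on two cores

A few compounds are considered here, and "the series" means these few. Any claim that something is new, unique, unknown or untested is made for them only; others in the source may bear on it.

Measured so far:
Compound 1, `CC(C)c1noc(N2CCC([C@H]3C[C@H]3COCc3ccc(S(C)(=O)=O)cc3F)CC2)n1`: in a physicochemical assay for solubility, in simulated intestinal fluid, measured as kinetic solubility, at pH 6.5 (on this read-out lower numbers stand for lower solubility and higher numbers for higher solubility), compound 1 gives 144000 nM.
Compound 2, `CC(C)c1noc(N2CCC([C@H]3C[C@H]3COCc3ccc(-n4cnnn4)cc3F)CC2)n1`: in this assay compound 2 gives 103000 nM.
Compound 3, `COCc1cnc(N2CCC([C@H]3C[C@H]3COCc3ccc(S(C)(=O)=O)c(F)c3)CC2)nc1`: in this assay compound 3 gives 155000 nM.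

Compound 2 differs from compound 1 by 1H-tetrazol-1-yl in place of methylsulfonyl on an aromatic carbon. The step was a 1.4-fold lower number from compound 1 to compound 2 (0.15 log units; within the scatter). Compound 3 and compound 1 carry different cores; the difference between the two cores is not broken down here. Their two values lie within the scatter of each other, as do those of compound 3 and compound 2.

Compound 4, `COCc1cnc(N2CCC([C@H]3C[C@H]3COCc3ccc(-n4cnnn4)c(F)c3)CC2)nc1`, has not yet been measured. It differs from compound 3 by 1H-tetrazol-1-yl in place of methylsulfonyl on an aromatic carbon. The place is not the same as in the earlier pair: here the entering group stands ortho to a fluoro group, while from compound 1 to compound 2 it stood meta to a fluoro group. It is the same kind of change, not the same change.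

The expected step is a 1.4-fold lower number from compound 3 to compound 4 (0.15 log units; within the scatter), set beside the measured 1.4-fold lower number from compound 1 to compound 2 (0.15 log units; within the scatter). This rests on the shown step alone, since no second pair on the core of compound 3 is known. Compound 4 is estimated at 110000 nM, expected between 70000 nM and 180000 nM.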

Compound 4, solubility: 133000 nM
Compound 4: the middle estimate sits 1.2-fold (0.08 log units) below what was measured; low and high end bracket the measured number.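

On the core of compound 3, 1H-tetrazol-1-yl in place of methylsulfonyl gives a 1.2-fold lower number from compound 3 to compound 4 (0.07 log units; within the scatter) in this assay, and the same kind of change on the core of compound 1 gives a 1.4-fold lower number from compound 1 to compound 2 (0.15 log units; within the scatter) on that read-out. Neither step lies beyond the scatter, so across these two pairs the change carries from one core to the other without a step that can be told from repeat-measurement noise, but two such pairs establish no rule for the series, and the place of the change relative to the fluoro group is not the same in them, so core and place cannot be separated. No measurement at hand explains these values.

The compounds shown leave open whether the same result holds on a third core or with the fluoro group's place held fixed. They also leave open whether a different entering group, such as a carboxylic acid or an amine in place of methylsulfonyl, gives a step beyond the scatter.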